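Sulfonyl aryl fluorination in the mGlu5 sulfone series

The source may report more compounds than this note shows. Statements on the series, on what has been measured and on what is new or still open speak of the compounds shown alone.

Compound 1 `CC1CCN(c2c(S(=O)(=O)c3ccccc3)cnc3ccc(F)cc23)CC1` has the lowest number of the three measured compounds in an assay on isolated protein for displacement of a labelled ligand from metabotropic glutamate receptor 5 (Homo sapiens), with a stated time of 60 min, tested at 1 uM (on this read-out higher numbers stand for more inhibition at the one concentration tested (going by the name of the read-out) and lower numbers for less inhibition), where compound 1 gives 40%. Its nearest neighbour is compound 2 `Cc1ccc2ncc(S(=O)(=O)c3ccccc3)c(N3CCC(C)CC3)c2c1`, which in this assay gives 67%, a rise of a number 27 percentage points higher from compound 1 to compound 2 (beyond the scatter). Furthest is compound 3 `CC1CCN(c2c(S(=O)(=O)c3ccccc3)cnc3ccccc23)CC1`, which in this assay gives 89.2%, a rise of a number 49.2 percentage points higher from compound 1 to compound 3 (beyond the scatter); between the two methyl compounds the step is a number 22.2 percentage points higher from compound 2 to compound 3 (beyond the scatter). All three measured steps concern fluoro, methyl or hydrogen on an aromatic carbon of the shared core.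

Compound 4 `CC1CCN(c2c(S(=O)(=O)c3ccc(F)c(F)c3)cnc3ccc(F)cc23)CC1` differs from compound 1 elsewhere: 3,4-difluorophenyl in place of phenyl on a sulfonyl sulfur. For the measured compounds named here, no measured step touches the group on the sulfonyl sulfur, so the measured steps set only the spread of the series, not the direction of this change. The expectation for compound 4 is therefore anchored on compound 1 because of its value of 40%, with a wide range to cover the unknown effect of the new aryl group. Compound 4 is estimated at 45% in this assay, from 15% to 75%, an expected step of a number 5 percentage points higher from compound 1 to compound 4 (within the scatter).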

Compound 4, a percentage reported as inhibition, at one concentration (the size of the read-out at that concentration, not a potency): 82%
Compound 4: the middle estimate sits 37 percentage points below what was measured; measured number outside the range, above it.
By their numbers in this assay, from the lowest: compound 1; then compound 2; then compounds 4 and 3 (each within the scatter of the next).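

For the compounds shown here, with 3,4-difluorophenyl in place of phenyl on a sulfonyl sulfur, this assay shows a number 42 percentage points higher from compound 1 to compound 4 (beyond the scatter), a large step at a place that none of the earlier steps touched. The group on the sulfonyl sulfur is therefore a second place in the series, besides the aromatic carbon of the shared core, where one change moves this read-out beyond the scatter. No measurement shown accounts for the size or direction of this step.

As far as these compounds go, whether a monofluorophenyl group would give a step of similar size, and whether the same change would hold on the core of compound 3, remains open. Also open, from the compounds shown here alone, is how a chlorophenyl or pyridyl group on the sulfonyl sulfur would compare with 3,4-difluorophenyl.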